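The source may report more compounds than this note shows. Statements on the series, on what has been measured and on what is new or still open speak of the compounds shown alone.

Compound 1 `CN(C(=O)C(C)(C)C)c1ccc2[nH]c(-c3n[nH]c4ccccc34)cc2n1` gives 22200 nM in a functional assay on SMMC-7721 cells (Homo sapiens) for antiproliferative activity, read by MTT assay, with a stated time of 72 h; a higher number here means a weaker inhibitor, a lower number a stronger inhibitor.
Compound 2 `COc1cccc(C(=O)N(C)c2ccc3[nH]c(-c4n[nH]c5ccccc45)cc3n2)c1` gives 22000 nM in this assay.
Compound 3 `CN(c1ccc2[nH]c(-c3n[nH]c4ccccc34)cc2n1)S(=O)(=O)c1ccccc1` gives 12000 nM in this assay.

Compound 3 has the lowest of the three numbers, yet both of its steps from the others stay within the scatter: a 1.9-fold lower number from compound 1 to compound 3 (0.27 log units; within the scatter) and a 1.8-fold lower number from compound 2 to compound 3 (0.26 log units; within the scatter). The exchange between the two carbonyl groups, a 1.0-fold lower number from compound 1 to compound 2 (0.00 log units; within the scatter), likewise moved nothing beyond the scatter. Compound 4 `CN(c1ccc2[nH]c(-c3n[nH]c4ccccc34)cc2n1)S(=O)(=O)c1cccc([N+](=O)[O-])c1` differs from compound 3 by nitro in place of hydrogen on an aromatic carbon. Among the compounds with values here, no measured step touches the phenyl of the phenylsulfonyl group; each swaps the entire group on the ring nitrogen, and all three numbers sit close together. The step from compound 3 to compound 4 is therefore expected to be small, no change at the digits printed from compound 3 to compound 4 (within the scatter), with no direction beyond the scatter. Compound 4 is estimated at 12000 nM, between 5000 nM and 30000 nM.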

Compound 4, half-maximal inhibitory concentration: 5070 nM
Estimate against measurement, compound 4: 2.4-fold (0.37 log units) above; measured number inside the range.
By their numbers in this assay, from the lowest: compound 4; then compounds 3, 2 and 1 (each within the scatter of the next).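

Nitro on the phenyl of the phenylsulfonyl group is the first change in this assay to go beyond the scatter, with a 2.4-fold lower number from compound 3 to compound 4 (0.37 log units; beyond the scatter), whereas every swap of the whole group on the ring nitrogen stayed within it. This aromatic carbon, meta to a large group, therefore responds to a substituent, though the step is modest. No evidence at hand accounts for this step. As far as these compounds go, whether an amine or a chlorine on this same carbon would give a similar step remains open, as does the effect of nitro elsewhere on that phenyl.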